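Pyrazole acids: amide nitrogen and benzyl ring changes

The source may report more compounds than this note shows. Statements on the series, on what has been measured and on what is new or still open speak of the compounds shown alone.

Measured compounds:
Compound 1, `Cc1ccc(CN(C)C(=O)c2nn(-c3ccc(F)cc3)c(OC[C@@H](O)C[C@@H](O)CC(=O)O)c2C(C)C)cc1`: 37 nM
Compound 2, `Cc1ccc(CNC(=O)c2nn(-c3ccc(F)cc3)c(OC[C@@H](O)C[C@@H](O)CC(=O)O)c2C(C)C)cc1`: 15 nM
Compound 3, `Cc1cccc(CNC(=O)c2nn(-c3ccc(F)cc3)c(OC[C@@H](O)C[C@@H](O)CC(=O)O)c2C(C)C)c1`: 4.9 nM

In an assay on microsomes from liver for inhibition of 3-hydroxy-3-methylglutaryl-coenzyme A reductase (Rattus norvegicus) (on this read-out lower numbers stand for stronger inhibition and higher numbers for weaker inhibition), compound 1 gives the highest number of the three. Compound 2 differs by hydrogen in place of methyl on an amide-type nitrogen, and the step is a 2.5-fold lower number from compound 1 to compound 2 (0.39 log units; beyond the scatter). Compound 3 differs from compound 2 by 3-methylphenyl in place of 4-methylphenyl, with a 3.1-fold lower number from compound 2 to compound 3 (0.49 log units; beyond the scatter); taken together, a 7.6-fold lower number from compound 1 to compound 3 (0.88 log units; beyond the scatter).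

Compound 4, `CC(C)c1c(C(=O)NCc2cccc(Cl)c2)nn(-c2ccc(F)cc2)c1OC[C@@H](O)C[C@@H](O)CC(=O)O`, is not yet measured. It differs from compound 1 as follows: (3-chlorobenzyl)amino in place of methyl(4-methylbenzyl)amino on a carbonyl carbon. Both earlier steps bear on this change, since compound 4 carries the amide hydrogen of compound 2 and a 3-substituted benzyl like compound 3. A step of roughly the size seen from compound 1 to compound 3 is therefore expected, toward lower numbers. For compound 4 the estimate is 5.5 nM, in the range 2 nM to 15 nM, which is expected to mean a 6.7-fold lower number from compound 1 to compound 4 (0.83 log units; beyond the scatter).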

Compound 4, half-maximal inhibitory concentration: 5.4 nM
Compound 4: middle estimate off by 1.0-fold (0.01 log units), on the high side; the measured number falls inside the stated range.
By their numbers in this assay, from the lowest: compounds 3 and 4 (each within the scatter of the next); then compound 2; then compound 1.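

In this assay, chloro in place of methyl on an aromatic carbon makes no difference beyond the scatter (a 1.1-fold higher number from compound 3 to compound 4 (0.04 log units; within the scatter)), so 3-chlorophenyl and 3-methylphenyl cannot be told apart here. The 3-chlorophenyl group still gives lower numbers than the earlier 4-methylphenyl amides (a 2.8-fold lower number from compound 2 to compound 4 (0.44 log units; beyond the scatter); a 6.9-fold lower number from compound 1 to compound 4 (0.84 log units; beyond the scatter)). No measurement shown here explains these steps.

On these data alone, it remains open whether a methoxy or nitrile group on that aromatic carbon would give a similar number. As far as these compounds go, it is also open whether 4-chlorophenyl would match the 4-methylphenyl of compound 2.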